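A Methyl Removed from an Aromatic Oxygen

The compounds below may be only part of what the source reports. "The series", "measured", "known", "first", "only" and "open" are said of these compounds alone.

Of the compounds shown here, two built on the same core have been measured for how strongly they hold back the growth of a human lung cancer cell line. Compound 1 `Cc1cc(O)cc(-c2nn(CC#N)cc2-c2ccnc(-c3ccc(Oc4ccccc4)cc3)c2)c1` gives 5070 nM in a functional assay on A549 cells (Homo sapiens) for inhibition, read by sulforhodamine B assay, with a stated time of 48 h; a lower number here means a stronger inhibitor of growth, a higher number a weaker inhibitor of growth. Compound 2 `COc1cc(C)cc(-c2nn(CC#N)cc2-c2ccnc(-c3ccc(N(C)C)cc3)c2)c1` gives 483000 nM in this assay, the higher of the two numbers and so the weaker inhibitor of growth, with a gap to compound 1 that lies well beyond the scatter. The two compounds differ in two places at once, so the numbers alone cannot say which part carries the gap.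

Compound 3 `Cc1cc(O)cc(-c2nn(CC#N)cc2-c2ccnc(-c3ccc(N(C)C)cc3)c2)c1` has not yet been measured. It arises from compound 2 by one change, (hydrogen in place of methyl on an oxygen on an aromatic ring), so that the ring which carried a methoxy now carries the hydroxy seen in compound 1. Because compound 1 reaches 5070 nM with that hydroxy in place, the step from compound 2 to compound 3 is expected to lower the number, by about a 9.7-fold lower number from compound 2 to compound 3 (0.98 log units; beyond the scatter). Compound 3 is therefore estimated at 50000 nM in this assay, within a range from 6000 nM to 300000 nM.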

Compound 3, concentration for total growth inhibition: 54500 nM
Estimate against measurement, compound 3: 1.1-fold (0.04 log units) below; measured number inside the range.
By their numbers in this assay, from the lowest: compound 1; then compound 3; then compound 2.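

Compound 3 separates the two differences between compound 1 and compound 2. In this assay, replacing methoxy with hydroxy on the 3-methoxy-5-methylphenyl group gives an 8.9-fold lower number from compound 2 to compound 3 (0.95 log units; beyond the scatter), so the loss of one methyl from this aromatic oxygen is enough to move the number beyond the scatter, with the rest of the molecule unchanged. With the hydroxy held constant, dimethylamino in place of phenoxy gives an 11-fold higher number from compound 1 to compound 3 (1.03 log units; beyond the scatter), also beyond the scatter, so the gap between compound 1 and compound 2 is not the work of one place alone, and compound 3 stands between them with one feature of each.

No measurement shown here gives a reason why either change moves the number. The compounds shown leave open whether the same removal of the methyl would give a step of similar size with phenoxy in place of dimethylamino, and how this aromatic oxygen would respond to a longer chain such as ethoxy, or to replacement of the hydroxy by an amine or a carboxylic acid.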